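A few compounds are considered here, and "the series" means these few. Any claim that something is new, unique, unknown or untested is made for them only; others in the source may bear on it.

In a functional assay on MCF7 cells (Homo sapiens) for antiproliferative activity, read by MTT assay, with a stated time of 24 h (on this read-out higher numbers stand for weaker inhibition and lower numbers for stronger inhibition), compound 1 (`Cc1ccc(-c2nn(-c3ccccc3)cc2-c2nc3ccccc3[nH]2)cc1`) gives 7260 nM. With a (4-fluorophenyl)sulfonyl group in place of hydrogen on an aromatic nitrogen, compound 2 (`Cc1ccc(-c2nn(-c3ccccc3)cc2-c2nc3ccccc3n2S(=O)(=O)c2ccc(F)cc2)cc1`) gives 5270 nM. Among the compounds with values here, the only measured step is a 1.4-fold lower number from compound 1 to compound 2 (0.14 log units; within the scatter), so compound 2 stands level with compound 1, its sole neighbour on these numbers.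

Compound 3 (`Cc1ccc(-c2nn(-c3ccccc3)cc2-c2nc3ccccc3n2S(=O)(=O)c2ccc(Cl)cc2)cc1`) has not yet been measured. It keeps the sulfonyl group of compound 2 but carries chloro in place of fluoro on an aromatic carbon, para to a large group, turning 4-fluorophenyl into 4-chlorophenyl: chloro in place of fluoro on an aromatic carbon. Within the data shown here, no measured pair tests this exchange directly, and the single available step bears on it only indirectly. That step, a 1.4-fold lower number from compound 1 to compound 2 (0.14 log units; within the scatter), came with adding the entire group, so exchanging one halogen for another is expected to give no step beyond the scatter, in either direction. The estimate corresponds to a 1.1-fold lower number from compound 2 to compound 3 (0.04 log units; within the scatter), an expected step of no real size. For compound 3 the expected value is 4800 nM, with an estimated range from 2300 nM to 10000 nM.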

Compound 3, half-maximal inhibitory concentration: 5930 nM
Estimate against measurement, compound 3: 1.2-fold (0.09 log units) below, within the range that was stated.
By their numbers in this assay, from the lowest: compounds 2, 3 and 1 (each within the scatter of the next).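

The halogen exchange on the sulfonyl group gives no separation in this assay (the step is a 1.1-fold higher number from compound 2 to compound 3 (0.05 log units; within the scatter)), so at this place, on an aromatic carbon para to a large group, chloro and fluoro cannot be told apart on these numbers. Setting the (4-chlorophenyl)sulfonyl group in place of hydrogen on an aromatic nitrogen also stays within the scatter (the step is a 1.2-fold lower number from compound 1 to compound 3 (0.09 log units; within the scatter)), so with either halogen the sulfonyl group stands level with the hydrogen it replaces. No measurement offered here accounts for these results, which therefore stay a plain record of three compounds standing level.

The compounds shown carry only fluoro and chloro at this place on the ring, so it remains open whether a methoxy group, an amine or a carboxylic acid there would give a step beyond the scatter. On these data alone, it also remains open whether a smaller group on the aromatic nitrogen, such as methylsulfonyl or acetyl, would stay level with the hydrogen or move away from it.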